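This account rests on a few compounds, and the source may have more. Where it says the series, first, only, none or still open, it means among the compounds named here.

Measured compounds in a functional assay on KYSE-70 cells for antiproliferative activity against KYSE-70 cell line (Homo sapiens), read by MTT assay, with a stated time of 72 h; on this read-out higher numbers stand for weaker inhibition and lower numbers for stronger inhibition:
compound 1 `O=C(Nc1ccc(Cl)cc1)c1cc(=O)[nH]c2cc(Br)ccc12` gives > 20000 nM, a limit of the assay.
compound 2 `O=C(Nc1ccc(OC(F)(F)F)cc1)c1cc(=O)[nH]c2cc(Br)ccc12` gives > 20000 nM, a limit of the assay.
compound 3 `O=C(Nc1cccc(Cl)c1)c1cc(=O)[nH]c2cc(Br)ccc12` gives > 20000 nM, a limit of the assay.

All three values sit at the limit described in the limit of > 20000 nM in this assay, at which 3 of the 3 values shown sit; none of them is a number, so no ordering among compound 1, compound 2 and compound 3 can be read. The change from compound 1 to compound 2 is trifluoromethoxy in place of chloro on an aromatic carbon. Its step that the two limits leave unreadable from compound 1 to compound 2 gives no size; both ends are limits. Compound 3 differs from compound 1 in its core by 3-chlorophenyl in place of 4-chlorophenyl on an amide-type nitrogen, and the step that the two limits leave unreadable from compound 1 to compound 3 likewise gives no size.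

Compound 4 `O=C(Nc1cccc(OC(F)(F)F)c1)c1cc(=O)[nH]c2cc(Br)ccc12` has not yet been measured. It differs from compound 3 by trifluoromethoxy in place of chloro on an aromatic carbon. This is the same kind of change as that from compound 1 to compound 2, not the same one: in compound 2 the trifluoromethoxy stands para to a large group, in compound 4 it stands meta to a large group.

The step from compound 3 to compound 4 is expected to be about a step that the limit leaves unreadable from compound 3 to compound 4, beside the earlier step that could not be sized. This expectation rests on compound 2, whose value > 20000 nM is a limit after the same kind of change. It also rests on compound 3, whose value > 20000 nM is a limit. Compound 4 is therefore expected to give roughly 30000 nM in this assay, most probably reported again only as a limit, with a plausible span from 10000 nM to 100000 nM.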

Compound 4, half-maximal inhibitory concentration: > 20000 nM
Compound 4: only a limit was reported; the forecaster's own chance of this, stated with the estimate: 85%; the middle value lies beyond the limit too.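

In this assay compound 4 gives > 20000 nM, a limit and not a number. The change from compound 3 to compound 4 therefore yields no readable step, and the series stands at a single ceiling: the limit of > 20000 nM in this assay, at which 4 of the 4 values shown sit.

The compounds shown leave open whether any change to the shared core or its substituents can give a measurable value, and how these four compounds rank.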